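Pyrazole Acids with Varied Aryl Groups in a Cell Assay

A few compounds are considered here, and "the series" means these few. Any claim that something is new, unique, unknown or untested is made for them only; others in the source may bear on it.

Measured compounds:
Compound 1, `CCSc1sc(-n2nc(C)c(Cc3ccccc3[N+](=O)[O-])c2C(=O)O)nc1-c1ccc(Cl)c(Cl)c1`: 59000 nM
Compound 2, `CC(=O)Nc1ccc(-c2c(C)nn(-c3nc(-c4ccc(Cl)c(Cl)c4)c(SC(C)C)s3)c2C(=O)O)cc1`: 139000 nM
Compound 3, `Cc1c(-c2cc(Cl)cc(Cl)c2)c(C(=O)O)nn1-c1nc(-c2cc(Cl)ccc2F)c(SC(C)C)s1`: 4800 nM

All three were tested in a functional assay on BJAB cells (Homo sapiens) for antiproliferative activity, with a stated time of 4 days; a higher number here means that more compound is needed for the effect, a lower number that less compound is needed. Compound 2 gives 139000 nM, the highest of the three numbers. Compound 1, the nearest to it, gives 59000 nM, a lower number that lies beyond the scatter. Compound 3, the furthest from it, gives 4800 nM, a much lower number. Compound 2 is thus the compound that needs the most material for the effect among those measured.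

The next compound is compound 4, `COc1cc(Cl)cc(-c2c(C)nn(-c3nc(-c4ccc(Cl)c(Cl)c4)c(SC(C)C)s3)c2C(=O)O)c1`. It differs from compound 2 in one place: 3-chloro-5-methoxyphenyl in place of 4-acetamidophenyl on an aromatic carbon. Going by the values given here, no measured pair shows this change by itself, so the expectation rests on the three numbers alone. Compound 3, which carries a 3,5-disubstituted phenyl at the same place together with a different group elsewhere, gives the lowest number, so a step to a lower number is expected for compound 4, estimated as a 7.0-fold lower number from compound 2 to compound 4 (0.84 log units; beyond the scatter). Compound 4 is expected to give about 20000 nM, with a range from 6000 nM to 70000 nM.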

Compound 4, half-maximal effective concentration: 760 nM
Compound 4: middle estimate off by 26-fold (1.42 log units), on the high side; the whole stated range lies above it.
By their numbers in this assay, from the lowest: compound 4; then compound 3; then compound 1; then compound 2.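

With the rest of the structure unchanged, 3-chloro-5-methoxyphenyl in place of 4-acetamidophenyl gives a 180-fold lower number from compound 2 to compound 4 (2.26 log units; beyond the scatter) in this assay. Going by these compounds alone, this is the first comparison here that isolates one place, and it shows that the aryl group on this aromatic carbon of the five-membered ring can by itself shift the number strongly, which compound 1, compound 2 and compound 3 could not show. The change also removes the hydrogen-bond donor of the leaving group and brings in a chlorine, but the two come together, so neither can be credited with the step. Nothing measured here accounts for its size. As far as these compounds go, whether 3-chlorophenyl or 3-methoxyphenyl alone would give a similar number remains open, as does the outcome of replacing the carboxy group with a carboxamide.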